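This account rests on a few compounds, and the source may have more. Where it says the series, first, only, none or still open, it means among the compounds named here.

Compound 1 `CCOC(=O)[C@H]1CCN(S(=O)(=O)c2ccc(S(=O)(=O)N(CC)CC)cc2)C1` gives 29200 nM in a functional assay on MIA PaCa-2 cells (Homo sapiens) for inhibition, read by MTT assay, with a stated time of 7 days; on this read-out lower numbers stand for stronger inhibition and higher numbers for weaker inhibition. Compound 2 `CCOC(=O)[C@@H]1CCCN(S(=O)(=O)c2ccc(S(=O)(=O)N(CC)C(C)C)cc2)C1` gives 1000 nM. Compound 3 `CCOC(=O)[C@@H]1CCCN(S(=O)(=O)c2ccc(S(=O)(=O)N(C)Cc3ccccc3)cc2)C1` gives > 30000 nM, which is a limit of this assay and not a number (the limit of > 30000 nM in this assay, at which 1 of the 3 values shown sits).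

Compound 3 thus stands at the weak end of what this assay reports. For the measured compounds named here, the one measured step that reaches it, an at least 30-fold higher number from compound 2 to compound 3 (1.47 log units; beyond the scatter), is large. Compound 4 `CCOC(=O)[C@@H]1CCCN(S(=O)(=O)c2ccc(S(=O)(=O)N(C)C)cc2)C1` differs from compound 3 by hydrogen in place of phenyl on a saturated chain carbon bound to a sulfonamide nitrogen. Going by the values given here, no measured step removes a phenyl at this position, so the bearing of the step to compound 3 on the present change is indirect, and the sulfonamide amine in compound 4 is smaller than that of compound 2 as well. Compound 4 is expected to give about 12000 nM, between 2500 nM and 40000 nM, a step of an at least 2.5-fold lower number from compound 3 to compound 4 (0.39 log units; beyond the scatter) being estimated, with a real chance of another limit.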

Compound 4, half-maximal inhibitory concentration: 900 nM
The estimate for compound 4 lay 13-fold (1.12 log units) above the measured number, outside the stated range (below it).
By their numbers in this assay, from the lowest: compounds 4 and 2 (each within the scatter of the next); then compound 1. At a limit, above all of these: compound 3.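

With benzyl cut back to methyl on the sulfonamide nitrogen, the read-out shows an at least 33-fold lower number from compound 3 to compound 4 (1.52 log units; beyond the scatter), so the methyl that both compounds carry there is not enough to reach the weak end, and that end goes with the phenyl. Dimethylamino and ethyl(isopropyl)amino on the sulfonyl sulfur do not separate, with a 1.1-fold lower number from compound 2 to compound 4 (0.05 log units; within the scatter). The first step is only a bound, since compound 3 sits at a limit: the limit of > 30000 nM in this assay, at which 1 of the 4 values shown sits.

Left open is whether a cyclohexylmethyl or a pyridylmethyl in place of benzyl would also read weak. Also open, on these data alone, is whether a morpholine on the sulfonyl sulfur would read like dimethylamino.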